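From tert-Butyl to Bromo: Expecting Compound 4

The compounds below may be only part of what the source reports. "The series", "measured", "known", "first", "only" and "open" are said of these compounds alone.

Among the compounds with values here, compound 1 `CC(C)(C)c1ccc(CNCCCNS(=O)(=O)c2cc(C(F)(F)F)cc(C(F)(F)F)c2)cc1` gives 2300 nM in a functional assay on HPAC cells (Homo sapiens) for inhibition, read by MTT assay, with a stated time of 72 h (a lower number here means a stronger inhibitor of growth, a higher number a weaker inhibitor of growth), the lowest of the three numbers measured so far. Compound 2 `O=S(=O)(NCCCNCc1ccc(C(F)(F)F)cc1)c1cc(C(F)(F)F)cc(C(F)(F)F)c1` gives 2700 nM in this assay, and the step of a 1.2-fold higher number from compound 1 to compound 2 (0.07 log units; within the scatter) is within the scatter. Compound 3 `O=S(=O)(NCCCNCc1ccccc1Cl)c1cc(C(F)(F)F)cc(C(F)(F)F)c1` gives 10000 nM in this assay; the step of a 4.3-fold higher number from compound 1 to compound 3 (0.64 log units; beyond the scatter) and the step of a 3.7-fold higher number from compound 2 to compound 3 (0.57 log units; beyond the scatter) are both beyond the scatter.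

Compound 4 `O=S(=O)(NCCCNCc1ccc(Br)cc1)c1cc(C(F)(F)F)cc(C(F)(F)F)c1` differs from compound 1 in one place: bromo in place of tert-butyl on an aromatic carbon. The change sits on an aromatic carbon, para to a large group, the same place where trifluoromethyl replaced tert-butyl in the step of a 1.2-fold higher number from compound 1 to compound 2 (0.07 log units; within the scatter), which stayed within the scatter. The steps to compound 3 concern a different group at a different place and so bear little on this change. Since one swap at this place has moved the number little, for compound 4 only a small step is expected in this assay, a 1.3-fold higher number from compound 1 to compound 4 (0.12 log units; within the scatter), likely within the scatter. Compound 4 is therefore estimated at 3000 nM, with a range from 1500 nM to 7000 nM.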

Compound 4, concentration for 50% growth inhibition: 2900 nM
The estimate for compound 4 lay 1.0-fold (0.01 log units) above the measured number; measured number inside the range.
By their numbers in this assay, from the lowest: compounds 1, 2 and 4 (each within the scatter of the next); then compound 3.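

In this assay, a single bromine atom can stand where the four carbons of tert-butyl stood with no step beyond the scatter (a 1.3-fold higher number from compound 1 to compound 4 (0.10 log units; within the scatter)), and bromo and trifluoromethyl also match (a 1.1-fold higher number from compound 2 to compound 4 (0.03 log units; within the scatter)), so three different groups at this place now give numbers within the scatter of one another. The step (a 3.4-fold lower number from compound 3 to compound 4 (0.54 log units; beyond the scatter)) lies beyond the scatter, so compound 3 stays apart from this group of three, although it swaps both the halogen and its place on the ring at once. Nothing measured here explains why the number holds across these groups.

From the compounds shown here alone, whether the gap to compound 3 follows the halogen or where it sits remains open. So does whether an amine or a carboxylic acid at this place would keep the number where it is.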